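The source may hold more compounds than are shown below. What is called first, only, known or untested is meant among the compounds shown, and "the series" means these compounds.

In a functional assay on MDA-MB-231 cells (Homo sapiens) for inhibition, read by sulforhodamine B assay, with a stated time of 48 h, tested at 1 uM (on this read-out lower numbers stand for a stronger effect and higher numbers for a weaker effect at the one concentration tested), three compounds of one series have been measured. Compound 1 `O=C(Nc1cccc(-n2cc(-c3ccncc3)c(-c3cc(O)cc(Cl)c3)n2)c1)Nc1ccc(Cl)c(C(F)(F)F)c1` gives 77%, compound 2 `O=C(Nc1cccc(-n2cc(-c3ccncc3)c(-c3cc(O)cc(Cl)c3)n2)c1)Nc1ccc(Cl)c(Cl)c1` gives 50%, and compound 3 `COc1cc(Cl)cc(-c2nn(-c3cccc(NC(=O)Nc4ccc(Cl)c(Cl)c4)c3)cc2-c2ccncc2)c1` gives 85%. Compound 3 thus shows the highest number of the three; its gap to compound 1 lies within the scatter, while its gap to compound 2 lies beyond it. Two single changes connect these numbers: a number 27 percentage points lower from compound 1 to compound 2 (beyond the scatter), with chloro in place of trifluoromethyl on an aromatic carbon, and a number 35 percentage points higher from compound 2 to compound 3 (beyond the scatter), with methyl in place of hydrogen on an oxygen on an aromatic ring.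

Compound 4 `COc1cc(Cl)cc(-c2nn(-c3cccc(NC(=O)c4cccc(C(F)(F)F)c4)c3)cc2-c2ccncc2)c1` differs from compound 3 in one place: 3-(trifluoromethyl)phenyl in place of (3,4-dichlorophenyl)amino on a carbonyl carbon. Going by the values given here, neither measured step alters the carbonyl carbon or its neighbours, so no measured step bears directly on this change. Both steps do show, however, that a single change in this series can move the read-out by a modest to large amount. Among the compounds with values here, with no step of the same kind to go by, compound 4 is expected to remain near compound 3, and the step of a number 5 percentage points lower from compound 3 to compound 4 (within the scatter) is estimated without a firm direction. Compound 4 is therefore estimated at 80%, within a range from 55% to 100%.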

Compound 4, a percentage reported as activity, at one concentration (the size of the read-out at that concentration, not a potency): 58%
Beside the measured number, compound 4's estimate is 22 percentage points above it; low and high end bracket the measured number.
By their numbers in this assay, from the lowest: compounds 2 and 4 (each within the scatter of the next); then compounds 1 and 3 (each within the scatter of the next).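

In this assay, the change on the carbonyl carbon, with 3-(trifluoromethyl)phenyl in place of (3,4-dichlorophenyl)amino, gives a number 27 percentage points lower from compound 3 to compound 4 (beyond the scatter), which shows that this position, untouched by the earlier single changes, also moves the read-out. The change is nevertheless not a simple one: the leaving group carries a hydrogen-bond donor and the entering group carries none, while chlorine gives way to fluorine and the amino nitrogen on the carbonyl carbon is lost, so this one step cannot separate these differences. Nothing in the data at hand gives a reason for the step.

Going by these compounds, whether the same change on the carbonyl carbon would shift the read-out in the same direction on the core of compound 2, which keeps the hydrogen on the oxygen where compound 3 and compound 4 carry methyl, remains open. Also open, on these data alone, is how an amine or a longer chain in place of 3-(trifluoromethyl)phenyl on the carbonyl carbon would read in this assay.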